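Swapping the Fluorinated Side Chain of Compound 2

This account rests on a few compounds, and the source may have more. Where it says the series, first, only, none or still open, it means among the compounds named here.

In a functional assay on HeLa cells (Homo sapiens) for cytotoxicity, read by WST assay, with a stated time of 48 h (on this read-out lower numbers stand for stronger inhibition and higher numbers for weaker inhibition), two compounds sharing one core have been measured so far. Compound 1 (`COc1cc(C(c2ccc(O)c(OC)c2)[C@@H](C)[C@@H](C)CF)ccc1O`) gives 42000 nM, and compound 2 (`COc1cc(C(c2ccc(O)c(OC)c2)[C@H](CF)C(C)C)ccc1O`) gives 19000 nM, the lower of the two numbers. Among the compounds with values here, the only measured step is a 2.2-fold lower number from compound 1 to compound 2 (0.34 log units; beyond the scatter). Compound 3 (`COc1cc(C(c2ccc(O)c(OC)c2)[C@@H](C)[C@H](C)CF)ccc1O`) has yet to be measured in this assay. In compound 3, 2-(fluoromethyl)-1-methylpropyl stands in place of the 1-(fluoromethyl)-2-methylpropyl of compound 2, on a saturated chain carbon bound to two aromatic carbons: 2-(fluoromethyl)-1-methylpropyl in place of 1-(fluoromethyl)-2-methylpropyl on a saturated chain carbon bound to two aromatic carbons. The entering group has the same name as the group in compound 1, but the two compounds differ in stereochemistry, and no measurement shows what that difference does. Within the data shown here, the one measured step bearing on this change is therefore the step between compound 1 and compound 2, taken in reverse. A modest rise of similar size is expected, with compound 1 at 42000 nM as the nearest guide. The expected change is a 2.0-fold higher number from compound 2 to compound 3 (0.30 log units; within the scatter). For compound 3 the estimated value is 38000 nM, with an expected range of 16000 nM to 90000 nM.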

Compound 3, half-maximal inhibitory concentration: 37000 nM
Compound 3: middle estimate off by 1.0-fold (0.01 log units), on the high side, within the range that was stated.
By their numbers in this assay, from the lowest: compounds 2, 3 and 1 (each within the scatter of the next, the first and the last beyond it).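

In this assay, replacing 1-(fluoromethyl)-2-methylpropyl with 2-(fluoromethyl)-1-methylpropyl on a saturated chain carbon bound to two aromatic carbons gives a 1.9-fold higher number from compound 2 to compound 3 (0.29 log units; within the scatter), so with this configuration the change of side chain does not clear the usual scatter, although the step between compound 1 and compound 2 did. Within the data shown here, the new pair also gives the first reading of configuration in this side chain, and it shows a 1.1-fold lower number from compound 1 to compound 3 (0.06 log units; within the scatter), so the stereocentre drawn differently leaves the two numbers indistinguishable here. This pair isolates that one stereocentre, and the reading rests on a single comparison, for which the structural basis is simply this: the fact that compounds 1 and 3 differ only in the configuration as drawn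

Going by these compounds, it remains open whether the other stereocentre of 2-(fluoromethyl)-1-methylpropyl would matter as little as this one, since both compounds that carry this side chain share its configuration. On these data alone, it also remains open whether an amine or a hydroxyl group in place of the fluorine, or a longer chain on the same carbon, would move the number beyond the scatter.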